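Swapping methoxy for fluoro on two cores

The source may hold more compounds than are shown below. What is called first, only, known or untested is meant among the compounds shown, and "the series" means these compounds.

Compound 1 `COc1ccccc1/C=C/C(=O)c1cc(NC(C)=O)ccc1O` and compound 2 `CC(=O)Nc1ccc(O)c(C(=O)/C=C/c2ccccc2F)c1` share one core; in an ADME assay on MT4 cells (Homo sapiens) for cytotoxicity, read by MTT assay, with a stated time of 4 days (on this read-out higher numbers stand for lower toxicity in this test and lower numbers for higher toxicity in this test), compound 1 gives 37800 nM and compound 2 gives 33800 nM. The change between them is fluoro in place of methoxy on an aromatic carbon, and it made a 1.1-fold lower number from compound 1 to compound 2 (0.05 log units; within the scatter). Compound 3 `COc1ccccc1-c1oc2ccc(N)cc2c(=O)c1O` has a different core; the difference between the two cores is not broken down here. In this assay compound 3 gives 222000 nM, the highest of the three numbers. Compound 4 `Nc1ccc2oc(-c3ccccc3F)c(O)c(=O)c2c1` is made from compound 3 by the same change, (fluoro in place of methoxy on an aromatic carbon). Because the first instance gave a 1.1-fold lower number from compound 1 to compound 2 (0.05 log units; within the scatter), compound 4 is expected to stay near compound 3, with an estimated step of a 1.1-fold lower number from compound 3 to compound 4 (0.05 log units; within the scatter). The estimate for compound 4 in this assay is 200000 nM, expected to fall between 90000 nM and 450000 nM.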

Compound 4, half-maximal cytotoxic concentration: 44500 nM
Estimate against measurement, compound 4: 4.5-fold (0.65 log units) above; measured number below the stated range.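

On the core of compound 3, fluoro in place of methoxy gave a 5.0-fold lower number from compound 3 to compound 4 (0.70 log units; beyond the scatter) in this assay, and a lower number here stands for higher toxicity in this test. The step did not carry over in size from one core to the other: the same change on two cores in this assay, a 1.1-fold lower number (0.05 log units; within the scatter) from compound 1 to compound 2 and a 5.0-fold lower number (0.70 log units; beyond the scatter) from compound 3 to compound 4, 4.5-fold (0.65 log units) apart, beyond the scatter of two such steps. With one pair on each core, this shows that the size of the step differed between these two cores, but it does not show why, or what the change would do on a third core.

Which difference between the two cores matters remains open. So does how another group in place of the methoxy, such as an amine or a chloro group, would behave on either core.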